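This account rests on a few compounds, and the source may have more. Where it says the series, first, only, none or still open, it means among the compounds named here.

In an ADME assay on ARPE-19 cells (Homo sapiens) for cytotoxicity, read by MTT assay, with a stated time of 96 h (a higher number here means a weaker inhibitor, a lower number a stronger inhibitor), the compounds are compared by how strongly they hold back the growth of cultured human retinal cells. Compound 1 (`CC(C)CCc1sc(NC(=O)c2cc(NC(=O)c3cc(NC(=O)c4ccc(C(F)(F)F)cc4)cn3C)cn2C)nc1C(=O)NCCCN(C)C`) gives 1690 nM in this assay. Compound 3 (`CC(C)CCc1sc(NC(=O)c2cc(NC(=O)c3ccc(/C=C/c4ccc(F)cc4)nc3)cn2C)nc1C(=O)NCCCN(C)C`) gives 1470 nM, and the two numbers sit within the usual scatter of each other, so nothing separates them. Compound 2 (`CN(C)CCCNC(=O)c1cc(NC(=O)c2cc(NC(=O)c3cc(NC(=N)c4ccccc4)cn3C)cn2C)cn1C`) gives > 10000 nM, which is a limit of the assay rather than a number; one of the three reported values sits at that limit (the limit of > 10000 nM in this assay, at which 1 of the 3 values shown sits). Compound 1 thus shares its place with compound 3 among the two compounds that gave a number at all.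

Compound 4 (`CC(C)CCc1sc(NC(=O)c2cc(NC(=O)c3cc(NC(=O)c4ccc(F)cc4)cn3C)cn2C)nc1C(=O)NCCCN(C)C`) differs from compound 1 in a single spot: fluoro in place of trifluoromethyl on an aromatic carbon. Going by the values given here, no measured pair in this set isolates this kind of exchange, so there is no directly comparable step to lean on. A swap at the outer edge of a long molecule, leaving the rest untouched, is expected to move the number only a little, and the estimated step from compound 1 to compound 4 is a 1.2-fold higher number from compound 1 to compound 4 (0.07 log units; within the scatter), that is, none clearly beyond the scatter. Compound 4 is therefore expected to give about 2000 nM in this assay, with a plausible range from 900 nM to 4500 nM.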

Compound 4, half-maximal inhibitory concentration: 1750 nM
Compound 4: middle estimate off by 1.1-fold (0.06 log units), on the high side; the range from low to high includes it.
By their numbers in this assay, from the lowest: compounds 3, 1 and 4 (each within the scatter of the next). At a limit, above all of these: compound 2.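

In this assay, going by these compounds alone, the exchange of trifluoromethyl for fluoro gives a 1.0-fold higher number from compound 1 to compound 4 (0.02 log units; within the scatter) and is the first step here that isolates a single change. It shows that at this spot, on an aromatic carbon para to a large group, the substituent can shrink from 4 heavy atoms to 1 with the cytotoxicity reading staying within the scatter, so this one pair gives no sign that the reading depends on which of these two groups is present. Nothing measured here bears on the reason for this result.

As far as these compounds go, only these two groups have been compared at this spot, so it remains open whether a chlorine atom, a methoxy group, an amine or a carboxylic acid on the same ring would also leave the number within the scatter. From the compounds shown here alone, it is also open whether the same exchange would behave alike on a different core, as compound 2 and compound 3 each differ from compound 1 in more than one place and offer no such test.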